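Two amides at the assay limit, a hydroxyphenyl to come

This account rests on a few compounds, and the source may have more. Where it says the series, first, only, none or still open, it means among the compounds named here.

Compound 1, `Cc1ccc(S(=O)(=O)N[C@@H](CC(=O)NC(C)(C)C)C(=O)NCCNC(=O)Nc2ccccc2)cc1`: > 11100 nM
Compound 2, `Cc1ccc(S(=O)(=O)N[C@@H](CC(=O)NC(C)(C)C)C(=O)NCCNC(=O)c2cc(Cl)ccc2Cl)cc1`: > 11100 nM

In an ADME assay on Karpas-1106P cells (Homo sapiens) for cytotoxicity (a higher number here means that more compound is needed for the effect, a lower number that less compound is needed), compound 1 gives only a limit of the assay, > 11100 nM. Compound 2 also gives only a limit, > 11100 nM. The step that the two limits leave unreadable from compound 1 to compound 2 is therefore unreadable, since (the limit of > 11100 nM in this assay, at which 2 of the 2 values shown sit). Compound 1 thus stands at the limit, and nothing more can be said of its place among the numbers shown.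

Compound 3, `Cc1ccc(S(=O)(=O)N[C@@H](CC(=O)NC(C)(C)C)C(=O)NCCNC(=O)c2ccccc2O)cc1`, has not yet been measured. It differs from compound 1 in one place: 2-hydroxyphenyl in place of anilino on a carbonyl carbon. Within the data shown here, the only measured step on this carbonyl carbon is the one from compound 1 to compound 2, and its size cannot be read, so no direction can be taken from it. For compound 3 the estimate is 15000 nM, with a range from 5000 nM to 50000 nM, and most probably again only a limit will be reported. This corresponds to an expected step that the limit leaves unreadable from compound 1 to compound 3.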

Compound 3, half-maximal effective concentration: > 11100 nM
Compound 3: no number, only a limit (the forecaster's own chance of this, stated with the estimate: 75%); the middle value lies beyond the limit too.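

In this assay compound 3 gives only a limit, > 11100 nM, so neither the step from compound 1 to compound 3 nor the step from compound 2 to compound 3 can be read: the limit of > 11100 nM in this assay, at which 3 of the 3 values shown sit. The compounds shown leave open whether any group on this carbonyl carbon changes the concentration needed for the effect.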